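The source may hold more compounds than are shown below. What is called first, only, known or untested is meant among the compounds shown, and "the series" means these compounds.

In a functional assay on T98G cells (Homo sapiens) for inhibition, read by colorimetric assay and MTT assay, with a stated time of 72 h (on this read-out higher numbers stand for weaker inhibition and lower numbers for stronger inhibition), three compounds have been tested so far. Compound 1 `COc1ccc2c(c1)-c1cnc(n1C)OCCCCCCCCO2` gives 68000 nM. Compound 2 `C=CCCCCOc1cc(F)ccc1-c1cnc(OCCC=C)n1C` returns > 100000 nM, which is a limit of the assay and not a true number. Compound 3 `CCCCOc1ncc(-c2ccccc2OC)n1C` gives 96000 nM, and this lies within the usual scatter of the value for compound 1, so repeated measurements could not reliably separate the two. With only these results, compound 3 stands among the high numbers seen so far, and high numbers here mean weak inhibition.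

The next compound, compound 4 `CCCCCCOc1ncc(-c2ccccc2OC)n1C`, differs from compound 3 in one place: ethyl in place of hydrogen on a saturated chain carbon, four bonds along the chain from an oxygen on an aromatic ring. In words, an ethyl takes the place of a hydrogen on a saturated chain carbon, four bonds along the chain from an oxygen on an aromatic ring. For the measured compounds named here, no two tested compounds differ in just one place, so no measured step shows what a change of this kind does in this assay.

The expectation therefore starts from compound 3 at 96000 nM and assumes only a small shift. The expected step, a 1.3-fold lower number from compound 3 to compound 4 (0.11 log units; within the scatter), is an estimate that leans slightly toward a lower number but stays within the scatter. For compound 4 the estimated value is 75000 nM, with an expected range from 30000 nM to 130000 nM.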

Compound 4, half-maximal inhibitory concentration: 58000 nM
The estimate for compound 4 lay 1.3-fold (0.11 log units) above the measured number; measured number inside the range.
By their numbers in this assay, from the lowest: compounds 4, 1 and 3 (each within the scatter of the next). At a limit, above all of these: compound 2.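

Placing an ethyl on a saturated chain carbon, four bonds along the chain from an oxygen on an aromatic ring, gives the only single-place step so far in this assay: a 1.7-fold lower number from compound 3 to compound 4 (0.22 log units; within the scatter). Since that step lies within the usual scatter, this one pair cannot tell the change apart from no effect on the read-out at this position, and both compounds remain among the high numbers that stand for weak inhibition here. Compound 2 sits at a limit, which is not a true number, so it cannot supply a measured step: the limit of > 100000 nM in this assay, at which 1 of the 4 values shown sits.

Going by these compounds, whether a different group on this chain carbon, such as an amine or a carboxylic acid, or a still longer chain would give a step beyond the scatter remains open. Also open, on these data alone, is whether the same ethyl change would give a similar step on a different core, since a single pair speaks only for the core shared by compound 3 and compound 4.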